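Hydrazinyl thiadiazole series: whole-animal dose, methyl(methylamino)amino analogue

The source may hold more compounds than are shown below. What is called first, only, known or untested is meant among the compounds shown, and "the series" means these compounds.

Measured compounds:
compound 1 `Cc1ccccc1-c1nnc(NN)s1`, 30 mg/kg
compound 2 `Cc1ccccc1-c1nnc(N(N)C(C)C)s1`, 49 mg/kg
compound 3 `Cc1ccccc1-c1nnc(NNC(C)C)s1`, 54 mg/kg

In a functional assay on the whole organism with Mus musculus as the target, with a stated time of 1 h (on this read-out lower numbers stand for an effect already at smaller amounts and higher numbers for an effect only at larger amounts of compound), compound 3 gives 54 mg/kg, the highest of the three numbers, but its steps to the others, a 1.8-fold higher number from compound 1 to compound 3 (0.26 log units; within the scatter) and a 1.1-fold higher number from compound 2 to compound 3 (0.04 log units; within the scatter), both lie within the scatter, so the three compounds cannot be separated on this read-out.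

Compound 4 `CNN(C)c1nnc(-c2ccccc2C)s1` has not yet been measured. Its difference from compound 3 is methyl(methylamino)amino in place of (isopropylamino)amino on an aromatic carbon. Within the data shown here, the steps that bear on it are the two isopropyl introductions, a 1.6-fold higher number from compound 1 to compound 2 (0.21 log units; within the scatter) and a 1.8-fold higher number from compound 1 to compound 3 (0.26 log units; within the scatter), and the swap of the isopropyl between the two nitrogens, a 1.1-fold higher number from compound 2 to compound 3 (0.04 log units; within the scatter); all three fall within the scatter. Substitution on either nitrogen of the hydrazinyl group has so far left this assay unchanged beyond the scatter, and nothing in the three compounds points to a direction for dimethylation. Compound 4 is therefore expected to give a number close to compound 3, a 1.1-fold lower number from compound 3 to compound 4 (0.03 log units; within the scatter). The estimate for compound 4 is 50 mg/kg, with a range from 25 mg/kg to 100 mg/kg.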

Compound 4, dose for half-maximal effect: 23 mg/kg
Compound 4: middle estimate off by 2.2-fold (0.34 log units), on the high side; the whole stated range lies above it.
By their numbers in this assay, from the lowest: compounds 4, 1, 2 and 3 (each within the scatter of the next, the first and the last beyond it).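

In this assay, among these compounds, methyl(methylamino)amino on the aromatic carbon gives the first changes at this position that go beyond the scatter, both modest: a 2.3-fold lower number from compound 3 to compound 4 (0.37 log units; beyond the scatter) and a 2.1-fold lower number from compound 2 to compound 4 (0.33 log units; beyond the scatter). The comparison with the unsubstituted group stays within the scatter, a 1.3-fold lower number from compound 1 to compound 4 (0.12 log units; within the scatter), so compound 4 separates only from the two isopropyl compounds and not from compound 1. No evidence on the origin of this difference is at hand.

Going by these compounds, compound 4 carries methyl on both nitrogens, so the contribution of each methyl cannot be told apart, and a single methyl on either nitrogen remains open. Also open, on these data alone, is how a larger change at this position, such as an acetyl group on the hydrazinyl nitrogen or a morpholine in place of the whole group, would read in this assay.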